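This account rests on a few compounds, and the source may have more. Where it says the series, first, only, none or still open, it means among the compounds named here.

Of the compounds shown here, two have been tested in a functional assay on the whole organism (strain albino) for inhibition, with Rattus norvegicus as the target, read by paw edema, with a stated time of 60 min, at a dose of 100 mg/kg by the oral route; a higher number here means more inhibition at the dose given (going by the name of the read-out), a lower number less inhibition. Compound 1 `Brc1ccc(NCc2nc3ccc(Br)cc3[nH]2)cc1` gives 20% in this assay. Compound 2 `Clc1cccc(NCc2nc3ccc(Br)cc3[nH]2)c1` gives 26.6% in this assay; the gap between compound 2 and compound 1 lies within the scatter, so the two numbers cannot be told apart. Compound 3 `Brc1ccc2nc(CNc3ccccc3)[nH]c2c1` is not yet measured. From compound 2 to compound 3 the change is hydrogen in place of chloro on an aromatic carbon. For the measured compounds named here, no measured pair covers this change, so its size is unknown. The expected step is a number 6.6 percentage points lower from compound 2 to compound 3 (within the scatter), a small fall or none beyond the scatter. Compound 3 is expected to give 20% in this assay, within 8% to 32%.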

Compound 3, a percentage reported as inhibition, in the whole organism at one dose (the size of the read-out at that dose, not a potency): 26.6%
For compound 3 the middle estimate is 6.6 percentage points below the measured one, within the range that was stated.
By their numbers in this assay, from the lowest: compounds 1, 2 and 3 (each within the scatter of the next).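

In this assay the swap of chloro for hydrogen, on an aromatic carbon meta to a large group, now has a measured size: no change at the digits printed from compound 2 to compound 3 (within the scatter). Hydrogen in place of bromo gives a number 6.6 percentage points higher from compound 1 to compound 3 (within the scatter), so at this dose neither halogen can be told apart from hydrogen. Nothing available bears on the reason for this result.

Still open, going by these compounds, is whether a different group on this ring, such as a methoxy group or a carboxylic acid, would give a step beyond the scatter. The compounds shown also leave open what replacing the bromo on the shared core would do.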